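Butyl in Place of Chloro: Expecting Permeability of Compound 3

The source may hold more compounds than are shown below. What is called first, only, known or untested is meant among the compounds shown, and "the series" means these compounds.

Of the compounds shown here, two have so far been tested in an ADME assay on Caco-2 cells (Homo sapiens) for permeability, in the apical to basolateral direction; a higher number here means that the compound crosses the layer faster, a lower number that the compound crosses the layer more slowly. Compound 1 `CNC(=O)c1cc(Oc2ccc3oc(Nc4cccc(C(F)(F)F)c4)nc3c2)ccn1` gives 10 10^-6 cm/s in this assay. Compound 2 `CNC(=O)c1cc(Oc2ccc3sc(Nc4ccc(Cl)cc4)nc3c2)ccn1` gives 10 10^-6 cm/s in this assay, level with compound 1 at the digits shown and within the usual scatter, so no order between the two is claimed. Compound 3 `CCCCc1ccc(Nc2nc3cc(Oc4ccnc(C(=O)NC)c4)ccc3s2)cc1` has not yet been measured. It differs from compound 2 in one place: butyl in place of chloro on an aromatic carbon. Going by the values given here, no pair of measured compounds shows this change, so nothing is known here about how the exchange of chloro for butyl moves permeability. With compound 2 giving 10 10^-6 cm/s as the only anchor, the step of a 1.1-fold lower number from compound 2 to compound 3 (0.05 log units; within the scatter) is expected to be small, with no direction that clearly exceeds the scatter. Compound 3 is therefore estimated at 9 10^-6 cm/s in this assay, with a range from 4 10^-6 cm/s to 20 10^-6 cm/s.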

Compound 3, apparent permeability: 10 10^-6 cm/s
The estimate for compound 3 lay 1.1-fold (0.05 log units) below the measured number, within the range that was stated.
By their numbers in this assay, from the lowest: compounds 1, 2 and 3 (each within the scatter of the next).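

The exchange of chloro for butyl on this aromatic carbon shows no change at the digits printed from compound 2 to compound 3 (within the scatter) in this assay. Going by these compounds alone, this is the first comparison here that changes one place only, since compound 1 and compound 2 differ in more than one place and could not isolate any single change. It shows that, for this pair, going from one heavy atom to a chain of four carbon atoms at this position leaves the read-out level, though nothing here gives a reason for that.

Going by these compounds, whether an amine or a carboxylic acid at the same position would also leave the number level remains open, as does the outcome for a longer chain. On these data alone, it is also open whether this exchange would give the same result on the core of compound 1.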